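A Single Inverted Stereocentre in a Weak Cytotoxic Series

This account rests on a few compounds, and the source may have more. Where it says the series, first, only, none or still open, it means among the compounds named here.

Compound 1 `C[C@H]1C(=O)OC[C@H]2[C@@H]1CC[C@@]2(C)O`: > 50000 nM
Compound 2 `C[C@@H]1C(=O)OC[C@H]2[C@@H]1C[C@H](O)[C@@]2(C)O`: 24500 nM

Among the compounds with values here, in a functional assay on HeLa cells (Homo sapiens) for cytotoxicity, read by MTT assay, with a stated time of 48 h (on this read-out higher numbers stand for weaker inhibition and lower numbers for stronger inhibition), compound 2 gives 24500 nM, the only true number available. For compound 1, the entry > 50000 nM is a limit of the assay and not a number.

The next compound, compound 3 `C[C@H]1C(=O)OC[C@H]2[C@@H]1C[C@H](O)[C@@]2(C)O`, has not yet been measured. Its relation to compound 2 is one of configuration alone: the two compounds have the same atoms and bonds and differ only in configuration as drawn: 1 of 5 stereo elements differ; a stereocentre at a saturated ring carbon is drawn S in compound 2 and R in compound 3. Within the data shown here, no measured pair shows what such an inversion does, so the expectation rests on compound 2, at 24500 nM. The expected step of a 1.2-fold higher number from compound 2 to compound 3 (0.09 log units; within the scatter) is small, leaning slightly toward weaker inhibition in this assay and probably not beyond the usual scatter. A result reported only as a limit remains possible. For compound 3 the estimated value is 30000 nM, with an expected range of 13000 nM to 60000 nM.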

Compound 3, half-maximal inhibitory concentration: > 50000 nM
Compound 3 gave a limit, no number; the forecaster's own chance of this, stated with the estimate: 35%; at least 1.6-fold (0.22 log units) between middle value and limit.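

In this assay the inversion of a stereocentre at a saturated ring carbon now has its first measured step, an at least 2.0-fold higher number from compound 2 to compound 3 (0.30 log units; that floor lies within the scatter), so the floor of this step does not by itself carry it beyond the scatter. Any difference between these two compounds can be set down to configuration alone, because nothing else separates them: the fact that compounds 2 and 3 differ only in the configuration as drawn. Going by these compounds, for compound 3, > 50000 nM is a limit of the assay and not a number, so the full size of the step remains unknown.

The step from compound 1 to compound 3, with hydroxy in place of hydrogen on a saturated ring carbon, cannot be read, as both entries are limits. On these data alone, what an amine or a methoxy group in place of that hydroxy would give in this assay stays open, as does the effect of inverting any other stereocentre.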